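Moving a methoxy group on a weakly cytotoxic acid

The compounds below may be only part of what the source reports. "The series", "measured", "known", "first", "only" and "open" are said of these compounds alone.

Compound 1 `COc1cccc(/C(=C\c2cn(C(C)=O)c3ccc(OCc4ccccc4)cc23)C(=O)O)c1` was tested in a functional assay on LNCaP cells (Homo sapiens) for cytotoxicity, read by MTT assay, with a stated time of 72 h (a lower number here means a stronger inhibitor, a higher number a weaker inhibitor), where compound 1 gives 65100 nM. Within the data shown here, this is the only number in the set, so compound 1 stands alone as the point of reference, and a value at this level marks it as a weak inhibitor of cell growth. Compound 2 `COc1ccc(/C(=C\c2c[nH]c3ccc(OCc4ccccc4)cc23)C(=O)O)cc1` was also part of the study, but in this assay compound 2 has "not determined" (no result reported), so it offers nothing to compare against.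

Compound 3 `COc1ccccc1/C(=C\c1cn(C(C)=O)c2ccc(OCc3ccccc3)cc12)C(=O)O` has not yet been measured. Its structure is built from the same atoms as compound 1, joined differently: 2-methoxyphenyl in place of 3-methoxyphenyl on a double-bonded chain carbon bound to a carbonyl carbon and a double-bonded chain carbon. Among the measured compounds shown here, no measured pair of compounds in this set shows what such a rearrangement does, so the expected size of the step rests on the single value of compound 1 alone. With nothing pointing one way or the other, the expected step of a 1.1-fold lower number from compound 1 to compound 3 (0.04 log units; within the scatter) is taken to lie within the scatter, with no preferred direction. Compound 3 is therefore estimated to give about 60000 nM, with a plausible range from 25000 nM to 150000 nM.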

Compound 3, half-maximal inhibitory concentration: 48500 nM
For compound 3 the middle estimate is 1.2-fold (0.09 log units) above the measured one; the range from low to high includes it.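

The pair gives the first measured view of this place on the molecule: in this assay, putting 2-methoxyphenyl in place of 3-methoxyphenyl on a double-bonded chain carbon bound to a carbonyl carbon and a double-bonded chain carbon gives a 1.3-fold lower number from compound 1 to compound 3 (0.13 log units; within the scatter). Since that step lies within the ordinary spread of repeated measurements, compound 1 and compound 3 cannot be told apart in this test, and relocating the methoxy group, with the same atoms kept and only their connection altered, leaves the reading where it was, at the weak level already seen. No independent measurement is available to explain why the two compounds read alike.

From the compounds shown here alone, what stays open is whether this place responds to anything beyond a shift of the methoxy group, for instance if an amine or a longer alkoxy chain such as butoxy took its place on the ring. A single pair also cannot show whether the same shift would read alike on a different core, so this result holds only for compound 1 and compound 3.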